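Swapping Amino for Sulfanyl on a Shared Nucleoside Core

The source may hold more compounds than are shown below. What is called first, only, known or untested is meant among the compounds shown, and "the series" means these compounds.

Measured compounds in a functional assay (Homo sapiens) for inhibition of Nucleic Acid, tested at 100 uM; a higher number here means more inhibition at the concentration tested (going by the name of the read-out), a lower number less inhibition:
Compound 1, `OC[C@H]1O[C@@H](n2cnc3c(NCc4ccccc4)nccc32)C[C@@H]1O`, gives 15%.
Compound 2, `[N-]=[N+]=Nc1nccc2c1ncn2[C@H]1C[C@H](O)[C@@H](CO)O1`, gives 4%.
Compound 3, `Nc1nccc2c1ncn2[C@H]1C[C@H](O)[C@@H](CO)O1`, gives 18%.

Compound 3 has the highest of the three numbers, though compound 1 sits within the scatter of it, so the two cannot be ordered; compound 2 lies clearly below both. The three compounds share one core and differ only in the group on one aromatic carbon. The new compound 4, `OC[C@H]1O[C@@H](n2cnc3c(S)nccc32)C[C@@H]1O`, keeps that core and carries sulfanyl in place of amino on an aromatic carbon.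

Among the measured compounds shown here, the steps that bear on this change are those at the same carbon: a number 11 percentage points lower from compound 1 to compound 2 (beyond the scatter), a number 14 percentage points higher from compound 2 to compound 3 (beyond the scatter), and a number 3 percentage points higher from compound 1 to compound 3 (within the scatter). Amino and benzylamino thus give similar inhibition, while azido gives less. Sulfanyl has no measured precedent here, so the expectation is uncertain: a small drop or no change beyond the scatter seems most likely, and compound 4 is expected to show a number 7 percentage points lower from compound 3 to compound 4 (within the scatter). Compound 4 is therefore estimated at 11%, within a range from 0% to 24%.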

Compound 4, a percentage reported as inhibition, at one concentration (the size of the read-out at that concentration, not a potency): 10%
For compound 4 the middle estimate is 1 percentage points above the measured one, and the stated range covers the measured number.
By their numbers in this assay, from the lowest: compounds 2, 4, 1 and 3 (each within the scatter of the next, the first and the last beyond it).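

In this assay, sulfanyl in place of amino on this aromatic carbon gives a number 8 percentage points lower from compound 3 to compound 4 (within the scatter) and so cannot be told from no change, even though sulfur replaces nitrogen with the same counted hydrogen-bond donor and acceptor. The comparisons with the other two groups read the same way: a number 6 percentage points higher from compound 2 to compound 4 (within the scatter) and a number 5 percentage points lower from compound 1 to compound 4 (within the scatter) are both unresolved. Sulfanyl thus falls within the scatter of both ends of the one clear gap among these groups, a number 14 percentage points higher from compound 2 to compound 3 (beyond the scatter), and cannot be sided with either end.

No measurement among these compounds offers an explanation for the numbers. From the compounds shown here alone, whether a hydroxyl or a methoxy group on this carbon would give a number clearly apart from these stays open.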